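A few compounds are considered here, and "the series" means these few. Any claim that something is new, unique, unknown or untested is made for them only; others in the source may bear on it.

Measured in a physicochemical assay for solubility, read by chemiluminescence, measured as kinetic solubility; on this read-out higher numbers stand for higher solubility and lower numbers for lower solubility:
Compound 1 `CC(=O)NCc1cccc(Cn2nc(NS(=O)(=O)c3ccc(Cl)s3)c3c(Cl)cccc32)c1`: >= 226 ug/mL, a limit.
Compound 2 `COc1cccc2c1c(NS(=O)(=O)c1ccc(Cl)s1)nn2Cc1cc(CNC(C)=O)ccn1`: >= 141 ug/mL, a limit.
Compound 3 `COc1cccc2c1c(NS(=O)(=O)c1ccc(Cl)s1)nn2Cc1ccnc(CNC(C)=O)c1`: >= 161 ug/mL, a limit.

None of these three compounds has a plain number in this assay, so their order cannot be read. Compound 3 stands on a limit of >= 161 ug/mL, and nothing more exact is known of it.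

Compound 4 `COc1cccc2c1c(NS(=O)(=O)c1ccc(Cl)s1)nn2Cc1cccc(CNC(C)=O)n1` has the same atoms as compound 3, joined differently: 6-(acetamidomethyl)pyridin-2-yl in place of 2-(acetamidomethyl)pyridin-4-yl on a saturated chain carbon bound to an aromatic nitrogen. Both groups hold one six-membered aromatic ring with 1 hetero atom and carry no net charge.

Going by the values given here, the only measured step that bears on this change is a step that the two limits leave unreadable from compound 2 to compound 3, another exchange of an acetamidomethyl-bearing pyridinyl group at the same place. That step offers no size to carry over, and it gives no direction. No step beyond the usual scatter is therefore expected in this assay, though this is a weakly supported expectation. It rests mainly on compound 3, whose limit is >= 161 ug/mL. The estimate is a step that the limit leaves unreadable from compound 3 to compound 4, which is expected to stay within the scatter. For compound 4 the estimated value is 170 ug/mL, with an expected range of 100 ug/mL to 260 ug/mL.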

Compound 4, solubility: >= 182 ug/mL
Compound 4: only a limit was reported (the forecaster's own chance of this, stated with the estimate: 70%); at least 1.0-fold (0.02 log units) between middle value and limit.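

In this assay, compound 4 gives >= 182 ug/mL, which is a limit. Its steps from compound 2 and from compound 3, which also stand on limits, cannot be read. The compounds shown leave open whether 4-(acetamidomethyl)pyridin-2-yl, 2-(acetamidomethyl)pyridin-4-yl and 6-(acetamidomethyl)pyridin-2-yl differ at all in this assay.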